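This account rests on a few compounds, and the source may have more. Where it says the series, first, only, none or still open, it means among the compounds named here.

Working notes on the series. Of the compounds shown here, three with the shared core have been measured: compound 1 `CCS(=O)(=O)Nc1cc(-c2ccc3ncnc(Nc4ccc(OC)c(Cl)c4)c3c2)cnc1OC`, compound 2 `CCS(=O)(=O)Nc1cc(-c2ccc3ncnc(Nc4ccc(OCc5ccc(F)cc5)c(Cl)c4)c3c2)cnc1OC` and compound 3 `CCCCS(=O)(=O)Nc1cc(-c2ccc3ncnc(Nc4cccc(C(=O)OCC)c4)c3c2)cnc1OC`. In a functional assay on A549 cells (Homo sapiens) for cytotoxicity, read by sulforhodamine B assay, with a stated time of 72 h (a lower number here means a stronger inhibitor, a higher number a weaker inhibitor), compound 1 gives 5240 nM. Compound 2 gives 31300 nM and compound 3 gives 42300 nM. Compound 1 thus stands lowest of the three numbers, with compound 2 nearest and compound 3 furthest from it, both beyond the scatter.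

The unmeasured compound 4 `CCS(=O)(=O)Nc1cc(-c2ccc3ncnc(Nc4ccc(OC)nc4)c3c2)cnc1OC` differs from compound 1 in one place: 6-methoxypyridin-3-yl in place of 3-chloro-4-methoxyphenyl on a nitrogen on an aromatic ring. Among the compounds with values here, only one single-site step is available, a 6.0-fold higher number from compound 1 to compound 2 (0.78 log units; beyond the scatter), and it alters the same arylamino group of compound 1 but not its ring. Within the data shown here, compound 3 differs from compound 1 in two places, so its value says only that a different arylamino group together with a longer sulfonamide chain sits well above compound 1. Among the measured compounds shown here, no measured step exchanges the aromatic ring on that nitrogen, so the expectation rests on the direction of the one neighbouring change.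

The step from compound 1 to compound 4 is expected to be a 1.7-fold higher number from compound 1 to compound 4 (0.23 log units; within the scatter), upward, since a 6.0-fold higher number from compound 1 to compound 2 (0.78 log units; beyond the scatter) also went upward on altering that group. Compound 4 is estimated at 9000 nM, with a range from 2500 nM to 32000 nM.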

Compound 4, half-maximal inhibitory concentration: 5560 nM
Beside the measured number, compound 4's estimate is 1.6-fold (0.21 log units) above it; the measured number falls inside the stated range.
By their numbers in this assay, from the lowest: compounds 1 and 4 (each within the scatter of the next); then compounds 2 and 3 (each within the scatter of the next).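

In this assay the exchange of 3-chloro-4-methoxyphenyl for 6-methoxypyridin-3-yl on the nitrogen gives a 1.1-fold higher number from compound 1 to compound 4 (0.03 log units; within the scatter) and so stays within the scatter: this position accepts a replacement of the aromatic ring itself, with the chlorine lost and a ring nitrogen entered, and the reading of compound 1 is kept. Within the data shown here, the only earlier single-site change at this group, a 6.0-fold higher number from compound 1 to compound 2 (0.78 log units; beyond the scatter) with 4-fluorophenyl placed on the oxygen-bound carbon, kept the ring and went beyond the scatter, so the two changes at this one group do not read alike. No supporting measurement accompanies this result to account for either reading.

The loss of the chlorine and the entry of the ring nitrogen arrive together in this one step, so the compounds shown do not separate the share of each. Also open, as far as these compounds go, is how an amine or a carboxylic acid in place of the methoxy group of 6-methoxypyridin-3-yl would read, and whether any group on this nitrogen can bring the number well under that of compound 1.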